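Chloro for cyano at the assay limit

This account rests on a few compounds, and the source may have more. Where it says the series, first, only, none or still open, it means among the compounds named here.

In an ADME assay on microsomes from liver (Homo sapiens) for metabolic stability, read by LC-MS, using NADPH, with a stated time of 10 min, tested at 10 uM (on this read-out lower numbers stand for a shorter-lived compound and higher numbers for a longer-lived compound), compound 1 `Nc1ncnc2c1c(Oc1cc(C(F)(F)F)ccn1)nn2C1CC1` gives > 2.41 h as a limit of the assay. In this assay compound 2 `N#Cc1ccnc(Oc2nn(C3CC3)c3ncnc(N)c23)c1` gives > 2.41 h as a limit too, so it has no number of its own. The evidence so far is the limit of > 2.41 h in this assay, at which 2 of the 2 values shown sit, and nothing more. Going by the values given here, the one measured step that the two limits leave unreadable from compound 1 to compound 2 has no readable size. Compound 3 `Nc1ncnc2c1c(Oc1cc(Cl)ccn1)nn2C1CC1` brings chloro in place of cyano on an aromatic carbon as its change, chloro in place of cyano on an aromatic carbon. No shift beyond the scatter is expected, and the estimated step is a step that the limit leaves unreadable from compound 2 to compound 3 in size. In this assay compound 3 is expected at 3 h with a range from 1.5 h to 6 h as its estimate.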

Compound 3, half-life: 1.05 h
Estimate against measurement, compound 3: 2.9-fold (0.46 log units) above; measured number outside the range, below it.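

In this assay, the aromatic carbon opposite the ring nitrogen proves sensitive to its substituent: chloro in place of cyano gives an at least 2.2-fold lower number from compound 2 to compound 3 (0.36 log units; beyond the scatter), and chloro in place of trifluoromethyl gives an at least 2.2-fold lower number from compound 1 to compound 3 (0.36 log units; beyond the scatter). Going by these compounds alone, compound 3 is therefore the only compound here with a half-life of its own. The step between the other two cannot be read, and both new steps have only a minimum size: the limit of > 2.41 h in this assay, at which 2 of the 3 values shown sit.

On these data alone, how far compound 1 and compound 2 lie beyond the limit remains open, as does whether an amine or a methoxy group at this carbon would behave like chloro or like cyano.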